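Chloro for methyl on the aryl sulfone: predicted cytotoxicity

A few compounds are considered here, and "the series" means these few. Any claim that something is new, unique, unknown or untested is made for them only; others in the source may bear on it.

Measured compounds:
compound 1 `Cc1ccc(S(=O)(=O)Cc2ncn(C)c2[N+](=O)[O-])cc1` gives > 846000 nM
compound 2 `Cn1cnc(CS(=O)(=O)c2ccc(Cl)cc2)c1[N+](=O)[O-]` gives 174000 nM
compound 3 `Cc1ccc(S(=O)(=O)Cc2nc(C)n(CCO)c2[N+](=O)[O-])cc1` gives 59000 nM

In an ADME assay on THP-1 cells (Homo sapiens) for cytotoxicity, read by flow cytometry and propidium iodide staining, with a stated time of 72 h (on this read-out higher numbers stand for weaker inhibition and lower numbers for stronger inhibition), compound 1 reaches only a limit of the assay and no number, > 846000 nM, which is recorded as the limit of > 846000 nM in this assay, at which 1 of the 3 values shown sits. Compound 2 gives 174000 nM in this assay. The two differ by a single change, (chloro in place of methyl on an aromatic carbon), and the step is an at least 4.8-fold lower number from compound 1 to compound 2 (0.68 log units; beyond the scatter). Because the first value is a limit (the limit of > 846000 nM in this assay, at which 1 of the 3 values shown sits), only the lower bound of that step is known.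

Compound 3 gives 59000 nM in this assay, which is the lowest number of the two actual numbers shown. The difference between the core of compound 3 and the core of compound 1 is not broken down here.

Compound 4 `Cc1nc(CS(=O)(=O)c2ccc(Cl)cc2)c([N+](=O)[O-])n1CCO` has not yet been measured. It differs from compound 3 by chloro in place of methyl on an aromatic carbon; the place is described in the same words as for the earlier pair, so this is the same change that turned compound 1 into compound 2. On the strength of that earlier step an at least 4.8-fold lower number from compound 1 to compound 2 (0.68 log units; beyond the scatter), compound 4 is expected to give a lower number than compound 3 in this assay, with an estimated step of a 3.3-fold lower number from compound 3 to compound 4 (0.52 log units; beyond the scatter). The estimate for compound 4 is 18000 nM, expected to lie between 6000 nM and 50000 nM.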

Compound 4, half-maximal inhibitory concentration: 578000 nM
Compound 4: the middle estimate sits 32-fold (1.51 log units) below what was measured; measured number above the stated range.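

In this assay, the change from 4-methylphenyl to 4-chlorophenyl gives a 9.8-fold higher number from compound 3 to compound 4 (0.99 log units; beyond the scatter), which runs opposite to the step seen on the core of compound 1, so on these two cores the change does not carry over in either size or direction: the same change on two cores in this assay, an at least 4.8-fold lower number (0.68 log units; beyond the scatter) from compound 1 to compound 2 and a 9.8-fold higher number (0.99 log units; beyond the scatter) from compound 3 to compound 4, at least 47-fold (1.67 log units) apart, beyond the scatter of two such steps. Compound 1 is recorded only as a limit, not as a number: the limit of > 846000 nM in this assay, at which 1 of the 4 values shown sits. The two pairs show that the outcome of this change differs with the core, but they do not show which feature of the core goes with the reversal, how large the earlier step really is, or which direction the change would take on a third core.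

The compounds shown leave open whether the reversal goes with the extra methyl on the core of compound 3, with its hydroxyl-bearing chain, or only with the two together, as these are not separated in any pair here. They also leave open how a fluoro or a methoxy in the same place on the aromatic ring, or an amine or a carboxylic acid in place of the hydroxyl on that chain, would read in this assay.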